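The compounds below may be only part of what the source reports. "The series", "measured", "known", "first", "only" and "open" are said of these compounds alone.

Within the data shown here, in a functional assay on HeLa cells (Homo sapiens) for antiproliferative activity, read by sulforhodamine B assay, with a stated time of 72 h (a higher number here means a weaker inhibitor, a lower number a stronger inhibitor), compound 3 `N#Cc1ccc(NC(=S)N/N=C/c2ccc3ccccc3n2)cc1` gives 20000 nM, the only actual number so far. Compound 1 `Fc1ccccc1NC(=S)N/N=C/c1ccc2ccccc2n1` reads > 100000 nM, which is a limit of the assay. Compound 2 `Cc1cccc(NC(=S)N/N=C/c2ccc3ccccc3n2)c1` reads > 100000 nM, also a limit. Compound 4 `S=C(N/N=C/c1ccc2ccccc2n1)Nc1cccc(Br)c1` has 3-bromophenyl in place of the 4-cyanophenyl of compound 3, on an amide-type nitrogen: 3-bromophenyl in place of 4-cyanophenyl on an amide-type nitrogen. Among the measured compounds shown here, two measured steps bear on this swap, since both end at 4-cyanophenyl: an at least 5.0-fold lower number from compound 1 to compound 3 (0.69 log units; beyond the scatter) and an at least 5.0-fold lower number from compound 2 to compound 3 (0.69 log units; beyond the scatter). Neither step tested 3-bromophenyl, but both suggest that giving up 4-cyanophenyl should move the number upward in this assay, by a modest amount. The expected change is a 2.0-fold higher number from compound 3 to compound 4 (0.30 log units; within the scatter). For compound 4 the estimated value is 40000 nM, with an expected range of 12000 nM to 100000 nM.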

Compound 4, half-maximal inhibitory concentration: 70000 nM
Compound 4: middle estimate off by 1.8-fold (0.24 log units), on the low side, within the range that was stated.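

In this assay, among these compounds, 3-bromophenyl on the amide-type nitrogen gives up part of what 4-cyanophenyl offers, a 3.5-fold higher number from compound 3 to compound 4 (0.54 log units; beyond the scatter), the first step at this place measured between two actual numbers. The other two steps, an at least 1.4-fold lower number from compound 2 to compound 4 (0.15 log units; that floor lies within the scatter) and an at least 1.4-fold lower number from compound 1 to compound 4 (0.15 log units; that floor lies within the scatter), show no real gain for compound 4, since their floors lie within the scatter. Both of these steps start from a limit of the assay, not a number: the limit of > 100000 nM in this assay, at which 2 of the 4 values shown sit.

Still open, from the compounds shown here alone, is whether 4-bromophenyl would read closer to compound 3 or compound 4. A phenyl ring carrying an amine or a carboxylic acid is also untested here.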